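Shortening the Ether Chain on the Shared Core

The source may report more compounds than this note shows. Statements on the series, on what has been measured and on what is new or still open speak of the compounds shown alone.

Compound 3 `CCCCCCCCCCCCCCCOC1(c2ccc(Cl)cc2)SC=C(C)n2c1noc2=O` is one of three compounds tested in a functional assay on A2780/DX3 cells (Homo sapiens) for antiproliferative activity, read by MTT assay, with a stated time of 3 days; a lower number here means a stronger inhibitor, a higher number a weaker inhibitor. In this assay compound 3 gives only a limit, > 100000 nM. Compound 1 `CC1=CSC(O)(c2cccc(C(F)(F)F)c2)c2noc(=O)n21` gives 71000 nM. Compound 2 `CC1=CSC(O)(c2ccccc2)c2noc(=O)n21` gives only a limit, > 100000 nM. Among the measured compounds shown here, the one measured step, an at least 1.4-fold higher number from compound 1 to compound 2 (0.14 log units; that floor lies within the scatter), concerns a different group on the shared core and is the only guide. Compound 4 `CCCCOC1(c2ccc(Cl)cc2)SC=C(C)n2c1noc2=O` differs from compound 3 by hydrogen in place of undecyl on a saturated chain carbon, four bonds along the chain from an oxygen on a saturated carbon. For the measured compounds named here, no measured step touches this chain, and two of the three values sit at the limit of > 100000 nM in this assay, at which 2 of the 3 values shown sit, so little change is expected, with compound 4 likely to give a limit again. The estimated step is a step that the limit leaves unreadable from compound 3 to compound 4. Compound 4 is expected to give 150000 nM, within 40000 nM to 500000 nM.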

Compound 4, half-maximal inhibitory concentration: 49000 nM
The estimate for compound 4 lay 3.1-fold (0.49 log units) above the measured number, within the range that was stated.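

This is the only step shown on the ether chain, and here the change has a readable outcome: in this assay, replacing undecyl with hydrogen gives an at least 2.0-fold lower number from compound 3 to compound 4 (0.30 log units; that floor lies within the scatter). That floor alone does not establish a real gain in potency. The true size of the step cannot be read because compound 3 gives only a limit: the limit of > 100000 nM in this assay, at which 2 of the 4 values shown sit.

On these data alone, whether a hexyl chain at this position would fall between compound 3 and compound 4 remains open. So does the effect of a chain ending in an amine.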